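A few compounds are considered here, and "the series" means these few. Any claim that something is new, unique, unknown or untested is made for them only; others in the source may bear on it.

Measured so far in a functional assay on THP-1 cells (Homo sapiens) for cytotoxicity, read by MTT assay, with a stated time of 48 h; on this read-out higher numbers stand for weaker inhibition and lower numbers for stronger inhibition: compound 1 `Fc1ccc(NC(=S)Nc2nc3ccccc3s2)cc1` and compound 3 `Fc1ccc(NC(=S)Nc2nc3ccc(F)cc3s2)cc1`. In this assay compound 1 gives 26700 nM. Compound 3 gives 34600 nM in this assay. Compound 2 `Cc1ccc2nc(Nc3nc4ccc(F)cc4s3)sc2c1` reaches only a limit of this assay, > 50000 nM.

Compound 3 sits beside compound 1; the step of a 1.3-fold higher number from compound 1 to compound 3 (0.11 log units; within the scatter) is within the scatter, and the third value shown is a limit (the limit of > 50000 nM in this assay, at which 1 of the 3 values shown sits), so compound 3 cannot be placed against it.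

Compound 4 `Fc1ccc2nc(NC(=S)Nc3ccccc3)sc2c1` differs from compound 3 by hydrogen in place of fluoro on an aromatic carbon; read one bond further out, 4-fluorophenyl becomes phenyl. For the measured compounds named here, the only measured step touching a fluoro, a 1.3-fold higher number from compound 1 to compound 3 (0.11 log units; within the scatter), concerns the shared core and stayed within the scatter. No step beyond the scatter is therefore expected for a 1.2-fold lower number from compound 3 to compound 4 (0.06 log units; within the scatter). Compound 4 is estimated at 30000 nM, with a range from 14000 nM to 60000 nM.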

Compound 4, half-maximal inhibitory concentration: 46600 nM
Compound 4: middle estimate off by 1.6-fold (0.19 log units), on the low side, and the stated range covers the measured number.
By their numbers in this assay, from the lowest: compounds 1, 3 and 4 (each within the scatter of the next). At a limit, above all of these: compound 2.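

Going from 4-fluorophenyl to phenyl gives a 1.3-fold higher number from compound 3 to compound 4 (0.13 log units; within the scatter) in this assay. This position, on an aromatic carbon para to a large group, therefore joins the fluoro change on the shared core in showing no step beyond the scatter. No measurement shown here bears on a cause for this step.

The compounds shown carry only fluoro or hydrogen at this position. On these data alone, whether an amine, a methoxy group or a carboxylic acid there would give a step beyond the scatter remains open.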